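The compounds below may be only part of what the source reports. "The series", "measured", "known", "first", "only" and "open" are said of these compounds alone.

Measured so far:

compound 1 `Cc1c(OCCCCOc2ccc(C(=O)O)cc2)ccc(C(=O)CC2CCCC2)c1O` — 82.6%
compound 2 `Cc1c(OCCCCOc2ccc(C(=O)O)cc2F)ccc(C(=O)CC2CCCC2)c1O` — 83.8%
compound 3 `Cc1c(OCCCCOc2ccc(C(=O)O)cc2Cl)ccc(C(=O)CC2CCCC2)c1O` — 82.2%

All three were tested in an assay on HEK293 cells for positive allosteric modulation of metabotropic glutamate receptor 2 (Rattus norvegicus), read by thallium flux, with a stated time of 2.5 min; on this read-out higher numbers stand for larger maximal responses and lower numbers for smaller maximal responses. On these numbers compound 3 stands lowest of the three, but the steps of a number 0.4 percentage points lower from compound 1 to compound 3 (within the scatter) and a number 1.6 percentage points lower from compound 2 to compound 3 (within the scatter) are both within the scatter, so the three compounds cannot be told apart. Compound 4 `Cc1c(OCCCCOc2cccc(C(=O)O)c2)ccc(C(=O)CC2CCCC2)c1O` is the next compound. It differs from compound 3 in one place: 3-carboxyphenyl in place of 4-carboxy-2-chlorophenyl on an oxygen on a saturated carbon. Two parts of this change can be weighed. Taking the chloro away reverses the step of a number 0.4 percentage points lower from compound 1 to compound 3 (within the scatter), and that step was within the scatter, as was a number 1.2 percentage points higher from compound 1 to compound 2 (within the scatter), where fluoro replaced hydrogen. Moving the carboxy group to the 3-carboxyphenyl arrangement has no counterpart among the measured steps, so this part of the change is untested. The expected step of a number 1.2 percentage points lower from compound 3 to compound 4 (within the scatter) is therefore none beyond the scatter, with a wider range to allow for the untested part. Compound 4 is expected to give 81% in this assay, between 62% and 92%.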

Compound 4, largest response reached (reported as percent of maximum), in percent of the reference or control that the assay uses: 80.6%
The estimate for compound 4 lay 0.4 percentage points above the measured number; measured number inside the range.
By their numbers in this assay, from the lowest: compounds 4, 3, 1 and 2 (each within the scatter of the next).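

Placing the acid as 3-carboxyphenyl rather than 4-carboxyphenyl on an oxygen on a saturated carbon gives a number 2 percentage points lower from compound 1 to compound 4 (within the scatter), so in this assay the two placements of the carboxy group cannot be told apart. The comparisons with the two halogen-bearing groups read a number 1.6 percentage points lower from compound 3 to compound 4 (within the scatter) and a number 3.2 percentage points lower from compound 2 to compound 4 (within the scatter), which means that this placement, with or without a halogen on the ring, leaves all four compounds indistinguishable on this read-out. No measurement at hand bears on the reason for this.

The compounds shown all keep a carboxylic acid on the ring, so it remains open whether a tetrazole or a primary amide in its place would give a similar maximal response. Going by these compounds, it is also open how a longer chain between the two oxygens would read here.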